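The compounds below may be only part of what the source reports. "The series", "measured", "known", "first", "only" and "open" are said of these compounds alone.

Measured so far in a functional assay on DU-145 cells (Homo sapiens) for inhibition; a higher number here means a weaker inhibitor, a lower number a stronger inhibitor:

Compound 1 `Oc1ccc(-c2cc(-c3cccc(F)c3)cc(-c3cccc(O)c3)n2)cc1` gives 2700 nM.
Compound 2 `Oc1ccc(-c2cc(-c3cccc(F)c3)cc(-c3ccc(O)cc3)n2)cc1` gives 9290 nM.
Compound 3 `Oc1ccc(-c2cc(-c3ccc(OC(F)(F)F)cc3)cc(-c3cccc(O)c3)n2)cc1` gives 18100 nM.

Compound 2 arises from compound 1 by one change, (4-hydroxyphenyl in place of 3-hydroxyphenyl on an aromatic carbon), and that step measures a 3.4-fold higher number from compound 1 to compound 2 (0.54 log units; beyond the scatter). Compound 4 `Oc1ccc(-c2cc(-c3ccc(OC(F)(F)F)cc3)cc(-c3ccc(O)cc3)n2)cc1` has not been measured yet; it arises from compound 3 by 4-hydroxyphenyl in place of 3-hydroxyphenyl on an aromatic carbon. The cores of compound 1 and compound 3 differ, but that difference is not broken down here. The surroundings of the place also differ: in compound 1 it is meta to a 3-fluorophenyl group, in compound 3 it is meta to a large group, so the two changes are the same kind of change rather than the same change. For compound 4 a step of about a 2.8-fold higher number from compound 3 to compound 4 (0.44 log units; beyond the scatter) in this assay is expected, resting on the earlier 3.4-fold higher number from compound 1 to compound 2 (0.54 log units; beyond the scatter). Compound 4 is therefore estimated at 50000 nM, likely between 18000 nM and 140000 nM.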

Compound 4, half-maximal inhibitory concentration: 5390 nM
Estimate against measurement, compound 4: 9.3-fold (0.97 log units) above; measured number outside the range, below it.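

In this assay, putting 4-hydroxyphenyl in place of 3-hydroxyphenyl gives a 3.4-fold lower number from compound 3 to compound 4 (0.53 log units; beyond the scatter). Set beside the earlier step, this change does not carry over from one core to the other, even in direction: the same change on two cores in this assay, a 3.4-fold higher number (0.54 log units; beyond the scatter) from compound 1 to compound 2 and a 3.4-fold lower number (0.53 log units; beyond the scatter) from compound 3 to compound 4, 12-fold (1.06 log units) apart, beyond the scatter of two such steps. Among these compounds, this shows that the effect of the change depends on the core it sits on, but with only two pairs it does not show which feature of the core turns the step around, or how large the step would be on any further core.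

The compounds shown leave open what an amine or a carboxylic acid would do in place of the hydroxyl group on these phenyl rings. They also leave open whether a core carrying a nitrile would follow either pair.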